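Chloropyridinyl sulfonamide estimated against the shared aminothiazole core

A few compounds are considered here, and "the series" means these few. Any claim that something is new, unique, unknown or untested is made for them only; others in the source may bear on it.

The series shares a core in which a propylamine bridge links a cyclohexyl sulfonamide to a fused aminothiazole, and it is assessed in an assay on brain for displacement of a labelled ligand from D(3) dopamine receptor (Rattus norvegicus); on this read-out lower numbers stand for stronger inhibition and higher numbers for weaker inhibition. Compound 1 `CCCN(CC[C@H]1CC[C@H](NS(=O)(=O)c2ccccc2)CC1)[C@H]1CCc2nc(N)sc2C1` carries a plain phenyl on the sulfonyl sulfur, and in this assay compound 1 gives 0.79 nM. Compound 2 `CCCN(CC[C@H]1CC[C@H](NS(=O)(=O)c2ccc(C(C)(C)C)cc2)CC1)[C@H]1CCc2nc(N)sc2C1` differs only by a tert-butyl on an aromatic carbon, and in this assay compound 2 gives 5 nM. Compound 2 thus stands at the higher of the two numbers measured, with a 6.3-fold higher number from compound 1 to compound 2 (0.80 log units; beyond the scatter).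

Compound 3 `CCCN(CC[C@H]1CC[C@H](NS(=O)(=O)c2ccc(Cl)nc2)CC1)[C@H]1CCc2nc(N)sc2C1` is not yet measured. The change is 6-chloropyridin-3-yl in place of 4-(tert-butyl)phenyl on a sulfonyl sulfur. For the measured compounds named here, no measured step covers a chloropyridinyl on the sulfonyl sulfur, so the only step that bears on it is a 6.3-fold higher number from compound 1 to compound 2 (0.80 log units; beyond the scatter), which shows that the tert-butyl that now leaves was accompanied by a higher number. Because of a 6.3-fold higher number from compound 1 to compound 2 (0.80 log units; beyond the scatter), compound 3 is expected to move back toward compound 1, with an estimated 3.3-fold lower number from compound 2 to compound 3 (0.52 log units; beyond the scatter). Compound 3 is estimated at 1.5 nM, within a range from 0.5 nM to 5 nM.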

Compound 3, inhibition constant: 0.63 nM
Compound 3: middle estimate off by 2.4-fold (0.38 log units), on the high side; measured number inside the range.
By their numbers in this assay, from the lowest: compounds 3 and 1 (each within the scatter of the next); then compound 2.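

On the sulfonyl sulfur, exchanging 4-(tert-butyl)phenyl for 6-chloropyridin-3-yl gives in this assay a 7.9-fold lower number from compound 2 to compound 3 (0.90 log units; beyond the scatter), so the higher number of compound 2 does not carry over to every substituted ring at this position. Against the plain phenyl of compound 1, the same group gives a 1.3-fold lower number from compound 1 to compound 3 (0.10 log units; within the scatter), which leaves compound 1 and compound 3 level: here, a ring with one hetero atom and a chlorine reads the same as an unsubstituted carbon ring, and among these three compounds only the tert-butyl group stands apart. Nothing available explains this result or accounts for the difference between the groups.

Compound 3 differs from compound 1 by both a ring nitrogen and a chlorine, and with neither a chlorophenyl nor a plain pyridinyl among the compounds shown, the two changes cannot be read separately. As far as these compounds go, it also remains open how the number would respond to an amine or a carboxylic acid in place of the chlorine, or to a methyl or a longer chain in place of the tert-butyl.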